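Chloro in place of fluoro on compound 3

The source may report more compounds than this note shows. Statements on the series, on what has been measured and on what is new or still open speak of the compounds shown alone.

In a functional assay on HCT-116 cells (Homo sapiens) for antiproliferative activity, read by MTT assay, with a stated time of 72 h (on this read-out lower numbers stand for stronger inhibition and higher numbers for weaker inhibition), compound 1 `O=C(CCc1cccc2c1B(O)OC2)Nc1ccccc1` gives 350 nM. Compound 2 `C#Cc1cccc(NC(=O)CCc2cccc3c2B(O)OC3)c1`, with ethynyl in place of hydrogen on an aromatic carbon, gives 3600 nM. Compound 3 `O=C(CCc1cccc2c1B(O)OC2)Nc1cccc(-c2cccc(F)c2)c1`, with 3-fluorophenyl in place of that hydrogen, gives 460 nM. Compound 3 therefore stands level with compound 1 and well apart from compound 2. The numbers show a 1.3-fold higher number from compound 1 to compound 3 (0.12 log units; within the scatter), and also a 7.8-fold lower number from compound 2 to compound 3 (0.89 log units; beyond the scatter).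

Compound 4 `O=C(CCc1cccc2c1B(O)OC2)Nc1cccc(-c2cccc(Cl)c2)c1` keeps everything in compound 3 except for one change, chloro in place of fluoro on an aromatic carbon, meta to a large group: chloro in place of fluoro on an aromatic carbon. Within the data shown here, no measured step makes this exact replacement, so the evidence is indirect. Adding the whole 3-fluorophenyl group produced a 1.3-fold higher number from compound 1 to compound 3 (0.12 log units; within the scatter). The one large move in the series is a 10-fold higher number from compound 1 to compound 2 (1.01 log units; beyond the scatter), and it shows that a change at an aromatic carbon can matter in this assay. That step involved a different group, however, and it says little about replacing a single halogen. No step beyond the scatter is therefore expected, and no direction is favoured. The expected step is a 1.0-fold lower number from compound 3 to compound 4 (0.01 log units; within the scatter). Compound 4 is estimated at 450 nM, with an expected range from 200 nM to 1000 nM.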

Compound 4, half-maximal inhibitory concentration: 350 nM
The estimate for compound 4 lay 1.3-fold (0.11 log units) above the measured number; low and high end bracket the measured number.
By their numbers in this assay, from the lowest: compounds 1, 4 and 3 (each within the scatter of the next); then compound 2.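

In this assay, the two halogens cannot be told apart on this aromatic carbon, meta to a large group, with a 1.3-fold lower number from compound 3 to compound 4 (0.12 log units; within the scatter). The 3-chlorophenyl group also stands level with the plain hydrogen, with no change at the digits printed from compound 1 to compound 4 (within the scatter), while ethynyl remains the outlier, with a 10-fold lower number from compound 2 to compound 4 (1.01 log units; beyond the scatter), so two different halogenated phenyl groups now match compound 1 and only the ethynyl group of compound 2 stands apart. The data shown hold no measurement that could account for this result.

Whether an amine or a carboxylic acid in place of the chloro of compound 4 would keep the number at the level shared by compound 1, compound 3 and compound 4 stays open, since both halogens shown are single atoms with no hydrogen-bond donors or acceptors. Going by these compounds, it is also open what a longer chain in place of ethynyl on compound 2 would do, and whether the level shared by these three compounds would hold in a cell line other than HCT-116.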